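Tosylate in Place of a Primary Hydroxyl on a Nitrophenyl Oxadiazole

The source may report more compounds than this note shows. Statements on the series, on what has been measured and on what is new or still open speak of the compounds shown alone.

Measured compounds:
Compound 1 `COc1cc(-c2nc(CO[C@@H]3O[C@H](CSc4ncn[nH]4)[C@H]4OC5(CCCC5)O[C@@H]34)no2)cc(OC)c1OC` gives 44000 nM in a functional assay on T47D cells (Homo sapiens) for antiproliferative activity, read by sulforhodamine B assay, with a stated time of 48 h; a higher number here means a weaker inhibitor of growth, a lower number a stronger inhibitor of growth.
Compound 2 `O=[N+]([O-])c1ccc(-c2nc(CO[C@@H]3O[C@H](CO)[C@H]4OC5(CCCC5)O[C@@H]34)no2)cc1` gives 50000 nM in this assay.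
Compound 3 `CC1(C)O[C@H]2[C@H](OCc3noc(-c4ccc([N+](=O)[O-])cc4)n3)O[C@H](CSc3ncn[nH]3)[C@H]2O1` gives > 100000 nM in this assay, a limit of the assay rather than a number.

Compound 2 holds the highest of the two numbers, and compound 1 sits nearest to it, within the scatter. Compound 4 `Cc1ccc(S(=O)(=O)OC[C@H]2O[C@@H](OCc3noc(-c4ccc([N+](=O)[O-])cc4)n3)[C@@H]3OC4(CCCC4)O[C@@H]32)cc1` differs from compound 2 by (4-methylphenyl)sulfonyl in place of hydrogen on an oxygen on a saturated carbon, the hydroxymethyl becoming (((4-methylphenyl)sulfonyl)oxy)methyl. Among the compounds with values here, no measured pair shows this change, so the step is expected to be small, no larger than the scatter, in either direction. Compound 4 is therefore estimated at 35000 nM, between 10000 nM and 100000 nM. The expected step, a 1.4-fold lower number from compound 2 to compound 4 (0.15 log units; within the scatter), is estimated to stay within the scatter.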

Compound 4, concentration for 50% growth inhibition: > 100000 nM
Compound 4 was reported as a limit; the forecaster's own chance of this, stated with the estimate: 25%; at least 2.8-fold (0.45 log units) between middle value and limit.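

In this assay compound 4 gives > 100000 nM, which is a limit of the assay and not a number. Putting (4-methylphenyl)sulfonyl in place of hydrogen on this oxygen gives an at least 2.0-fold higher number from compound 2 to compound 4 (0.30 log units; that floor lies within the scatter), so this change brings no stronger growth inhibition here, although the floor of the step lies within the scatter. The true size of the step stays unresolved: the limit of > 100000 nM in this assay, at which 2 of the 4 values shown sit.

On these data alone, what an amine or a carboxylic acid would give in place of the hydroxyl remains open. So does the effect of a smaller sulfonyl group, such as methanesulfonyl, on this oxygen.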